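From Phenyl to 3,4-Dimethoxyphenyl on the Shared Core

The source may hold more compounds than are shown below. What is called first, only, known or untested is meant among the compounds shown, and "the series" means these compounds.

- Compound 1 `Cc1ccc(C(=O)N2N=C(c3ccccc3)CC2c2cn(C)c3ccccc23)cn1` gives 1220 nM
- Compound 2 `Cn1cc(C2CC(c3ccccc3)=NN2C(=O)c2cccnc2)c2cc(Br)ccc21` gives 2520 nM

Among the measured compounds shown here, in a functional assay on HepG2 cells (Homo sapiens) for inhibition, read by MTT assay, with a stated time of 48 h (on this read-out lower numbers stand for stronger inhibition of growth and higher numbers for weaker inhibition of growth), only two compounds have been measured so far. Compound 2, at 2520 nM, holds the higher of the two numbers. Its gap to compound 1, at 1220 nM, lies just beyond the usual scatter. The next compound to be tested is compound 3 `COc1ccc(C2=NN(C(=O)c3cccnc3)C(c3cn(C)c4ccc(Br)cc34)C2)cc1OC`, which carries 3,4-dimethoxyphenyl in place of phenyl on a carbon with a double bond to nitrogen. For the measured compounds named here, no measured pair in this small set shows what such a change does, so the expectation remains loose. In this assay the expected change is a 1.3-fold lower number from compound 2 to compound 3 (0.10 log units; within the scatter), which would lie within the scatter. Compound 3 is estimated at 2000 nM, with an expected range from 700 nM to 6000 nM.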

Compound 3, concentration for 50% growth inhibition: 2450 nM
Estimate against measurement, compound 3: 1.2-fold (0.09 log units) below, within the range that was stated.
By their numbers in this assay, from the lowest: compounds 1, 3 and 2 (each within the scatter of the next, the first and the last beyond it).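

In this assay, putting 3,4-dimethoxyphenyl in place of phenyl on the carbon with a double bond to nitrogen gives a 1.0-fold lower number from compound 2 to compound 3 (0.01 log units; within the scatter). Among the compounds shown here, this is the first step read at this position, and it shows that the larger group, which brings hydrogen-bond acceptors that phenyl lacks, leaves the number within the scatter on this bromine-bearing core. No supporting measurement bears on this result.

Going by these compounds, whether an amine or a carboxylic acid on the phenyl ring at this carbon would give a step beyond the scatter remains open, as does how a single methoxy group would read there. Also open, on these data alone, is whether the same exchange would read alike with a group other than the (pyridin-3-yl)carbonyl group on the shared core.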